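The compounds below may be only part of what the source reports. "The series", "measured", "known", "first", "only" and "open" are said of these compounds alone.

Compound 1, `O=C(CCCSC[C@H](NC(=O)OCc1ccccc1)C(=O)Nc1ccccc1)NO`: in an assay on Sf9 cells for inhibition of histone deacetylase 9 (Homo sapiens), read by fluorescence, with a stated time of 1 h (a lower number here means a stronger inhibitor, a higher number a weaker inhibitor), compound 1 gives > 200 nM, which is a limit of the assay and not a number.
Compound 2, `O=C(CCCSC[C@H](NC(=O)OCc1ccccc1)C(=O)Nc1cccc2ccccc12)NO`: in this assay compound 2 gives > 200 nM, again a limit rather than a number.

Going by the values given here, compound 1 therefore stands at a limit in this assay, and the only other value shown is a limit as well, so its place among the numbers cannot be fixed more closely than that; this is summed up by the limit of > 200 nM in this assay, at which 2 of the 2 values shown sit. Among the compounds with values here, the one measured step, a step that the two limits leave unreadable from compound 1 to compound 2, is left unreadable by the two limits and gives no size in either direction.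

Compound 3, `O=C(CCCSC[C@H](NC(=O)c1ccccc1)C(=O)Nc1ccccc1)NO`, differs from compound 1 by phenyl in place of benzyloxy on a carbonyl carbon. Within the data shown here, no measured step touches the carbonyl carbon in question, and the only step that is measured at all has no readable size, so there is nothing on which to build an expectation of a change beyond the scatter in this assay. The estimate for compound 3 must therefore rest on compound 1 alone, which sits at > 200 nM.

On that basis compound 3 is expected to give about 500 nM in this assay, within 150 nM to 3000 nM, most likely again as a limit. The implied step that the limit leaves unreadable from compound 1 to compound 3 is likewise only an expectation.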

Compound 3, half-maximal inhibitory concentration: > 200 nM
Compound 3: no number, only a limit; the forecaster's own chance of this, stated with the estimate: 70%; the middle value lies beyond the limit too.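

In this assay compound 3 gives > 200 nM, which is a limit of the assay and not a number. No step can be read from compound 1 to compound 3, and the values shown offer no comparison: the limit of > 200 nM in this assay, at which 3 of the 3 values shown sit.

The compounds shown leave open how strongly each inhibits and whether either change, benzoyl for benzyloxycarbonyl or naphthalen-1-yl for phenyl, alters that.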